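A few compounds are considered here, and "the series" means these few. Any claim that something is new, unique, unknown or untested is made for them only; others in the source may bear on it.

Within the data shown here, compound 3 `O=C(Nc1ccc(Cl)c(-c2nnc3c(Cl)cccn23)c1)c1cccc(Cl)c1` is the only member of this set with a numerical reading: in a functional assay on T47D cells (Homo sapiens) for antiproliferative activity, read by MTT assay, with a stated time of 72 h (a lower number here means a stronger inhibitor, a higher number a weaker inhibitor), compound 3 gives 30200 nM. Compound 1 `O=C(Nc1ccc(Cl)c(-c2nnc3c(Cl)cccn23)c1)c1ccc(F)cc1Cl` reaches only the limit of this assay, giving > 100000 nM. Compound 2 `Cc1nc(C(=O)Nc2ccc(Cl)c(-c3nnc4c(Cl)cccn34)c2)cs1` likewise sits at the limit, with > 100000 nM. The 3-chlorophenyl amide therefore stands apart, with an at least 3.3-fold lower number from compound 1 to compound 3 (0.51 log units; beyond the scatter) and an at least 3.3-fold lower number from compound 2 to compound 3 (0.51 log units; beyond the scatter), while a step that the two limits leave unreadable from compound 1 to compound 2. Compound 4 `Cc1cc(Cl)ccc1C(=O)Nc1ccc(Cl)c(-c2nnc3c(Cl)cccn23)c1` differs from compound 3 by 4-chloro-2-methylphenyl in place of 3-chlorophenyl on a carbonyl carbon. The measured step that bears on this change is the one from 2-chloro-4-fluorophenyl to 3-chlorophenyl, an at least 3.3-fold lower number from compound 1 to compound 3 (0.51 log units; beyond the scatter), and the 4-chloro-2-methylphenyl of compound 4 resembles the 2-chloro-4-fluorophenyl of compound 1 in its substitution pattern more than it resembles 3-chlorophenyl, so the reverse of that step is the nearer comparison. Compound 4 is accordingly expected to move back toward the limit, with an estimate of 70000 nM spanning 20000 nM to 200000 nM. The expected step of a 2.3-fold higher number from compound 3 to compound 4 (0.37 log units; beyond the scatter) is thus a move to a weaker inhibitor, with a real chance that only a limit is reported.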

Compound 4, half-maximal inhibitory concentration: > 100000 nM
Compound 4 was reported as a limit (the forecaster's own chance of this, stated with the estimate: 40%); middle value at least 1.4-fold (0.15 log units) away from the limit.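

Compound 4 gives only a limit in this assay, and 4-chloro-2-methylphenyl in place of 3-chlorophenyl on this carbonyl carbon gives an at least 3.3-fold higher number from compound 3 to compound 4 (0.51 log units; beyond the scatter). Compound 3 now stands apart from two differently substituted phenyl amides as well as from the 2-methyl-1,3-thiazol-4-yl amide, though the steps linking compound 4 to compound 1 and compound 2 cannot be read. The picture of this position is therefore bounded on one side only: the limit of > 100000 nM in this assay, at which 3 of the 4 values shown sit.

As far as these compounds go, how far compounds 1, 2 and 4 lie beyond that limit remains open, as does which part of 4-chloro-2-methylphenyl, the methyl or the chlorine, goes with the change. Also open, from the compounds shown here alone, is whether an amine, a carboxylic acid or a longer alkyl chain on this carbonyl carbon would give a stronger inhibitor than compound 3 at 30200 nM.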